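The source may report more compounds than this note shows. Statements on the series, on what has been measured and on what is new or still open speak of the compounds shown alone.

Measured so far:
- compound 1, `COc1ccc(-c2nc(N)c3nn(-c4ccccc4)cc3n2)cc1`: 33%
- compound 2, `O=c1[nH]c(-c2ccccc2)nc2nn(-c3ccccc3)nc12`: 8%

Both compounds were tested in an assay on CHO cells for displacement of a labelled ligand from adenosine receptor A1 (Homo sapiens), read by scintillation counting, with a stated time of 120 min, tested at 1 uM; on this read-out lower numbers stand for less inhibition and higher numbers for more inhibition at the one concentration tested (going by the name of the read-out). Compound 1, whose structure is `COc1ccc(-c2nc(N)c3nn(-c4ccccc4)cc3n2)cc1`, gives 33% in this assay. Compound 2, `O=c1[nH]c(-c2ccccc2)nc2nn(-c3ccccc3)nc12`, gives 8%. Going by the values given here, of the two numbers, the one for compound 1 is the higher, and its distance to compound 2 lies beyond the usual scatter of this kind of measurement; the two compounds differ in several places at once, so no single structural change can be tied to that gap.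

The compound not yet measured is compound 3, `COc1ccc(C(=O)Nc2nc(-c3ccc(OC)cc3)nc3cn(-c4ccccc4)nc23)cc1`. It differs from compound 1 in one place: (4-methoxyphenyl)carbonyl in place of hydrogen on a nitrogen on an aromatic ring. Among the compounds with values here, for this change no measured pair exists to lean on, so the size and direction of its effect are open. The step from compound 1 to compound 3 is expected to be about a number 12 percentage points higher from compound 1 to compound 3 (beyond the scatter), an upward move of roughly the size of the scatter, and compound 3 is estimated at 45%, within a range from 15% to 80%.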

Compound 3, a percentage reported as inhibition, at one concentration (the size of the read-out at that concentration, not a potency): 3%
Compound 3: middle estimate off by 42 percentage points, on the high side; measured number below the stated range.
By their numbers in this assay, from the lowest: compounds 3 and 2 (each within the scatter of the next); then compound 1.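

Going by these compounds alone, the amino group of compound 1 is the first place where a single change can be read. In this assay, replacing one hydrogen on that nitrogen with (4-methoxyphenyl)carbonyl gives a number 30 percentage points lower from compound 1 to compound 3 (beyond the scatter), so this substitution on the nitrogen lowers the reading rather than raising it, and the free amino group goes with the higher number of this pair. Nothing available here gives a reason for this drop.

The compounds shown leave open which part of the new group goes with the loss, the carbonyl or the methoxyphenyl ring it carries: an acetyl group on the same nitrogen would keep the carbonyl without the ring, while a benzyl group would keep a ring without the carbonyl. They also leave open whether a plain methyl group on that nitrogen would lower the reading in the same way, or whether the hydrogen there can be replaced at all without a loss in this assay.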